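The compounds below may be only part of what the source reports. "The series", "measured", "known", "first", "only" and "open" are said of these compounds alone.

Measured in a functional assay on HCT-116 cells (Homo sapiens) for cytotoxicity, read by MTT assay, with a stated time of 72 h; on this read-out higher numbers stand for weaker inhibition and lower numbers for stronger inhibition:
compound 1 `Cc1ccc(S(=O)(=O)n2cc(COC3=C/C(=N\c4ccc(I)cc4)c4ccccc4C3=O)nn2)cc1`: > 16300 nM (a limit of the assay, not a number)
compound 2 `Cc1ccc(/N=C2\C=C(OCc3cn(S(=O)(=O)c4ccc(C)cc4)nn3)C(=O)c3ccccc32)cc1`: 3610 nM
compound 3 `COc1ccc(/N=C2\C=C(OCc3cn(S(=O)(=O)c4ccc(C)cc4)nn3)C(=O)c3ccccc32)cc1`: 7430 nM

Of the two compounds with a true number, compound 3 holds the higher one, and its nearest neighbour is set apart by a 2.1-fold higher number from compound 2 to compound 3 (0.31 log units; beyond the scatter). The next compound is compound 4 `Cc1ccc(S(=O)(=O)n2cc(COC3=C/C(=N\c4ccc(Cl)cc4)c4ccccc4C3=O)nn2)cc1`, which carries chloro in place of methoxy on an aromatic carbon, para to a large group: chloro in place of methoxy on an aromatic carbon.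

All three measured steps fall at this same place. The step between the methyl and methoxy compounds is modest, as shown above. The other two, an at least 4.5-fold lower number from compound 1 to compound 2 (0.65 log units; beyond the scatter) and an at least 2.1-fold lower number from compound 1 to compound 3 (0.34 log units; beyond the scatter), both start from the iodo compound and so give only a bound on their size. Among the compounds with values here, no chloro compound has been measured yet, and the series holds just three members, so any reading of it stays tentative. A slight lean toward a higher number rests on compound 1 and on an at least 2.1-fold lower number from compound 1 to compound 3 (0.34 log units; beyond the scatter). The expected step is a 1.2-fold higher number from compound 3 to compound 4 (0.08 log units; within the scatter), so no step beyond the scatter is anticipated. For compound 4 the estimate is 9000 nM, with an expected range of 4000 nM to 18000 nM.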

Compound 4, half-maximal inhibitory concentration: 9440 nM
Beside the measured number, compound 4's estimate is 1.0-fold (0.02 log units) below it, within the range that was stated.
By their numbers in this assay, from the lowest: compound 2; then compounds 3 and 4 (each within the scatter of the next). At a limit, above all of these: compound 1.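

In this assay, the change from 4-methoxyphenyl to 4-chlorophenyl gives a 1.3-fold higher number from compound 3 to compound 4 (0.10 log units; within the scatter), so chloro and methoxy are not told apart at this position. Methyl now stands apart from two other groups at this place, with a 2.6-fold higher number from compound 2 to compound 4 (0.42 log units; beyond the scatter) alongside the earlier 2.1-fold higher number from compound 2 to compound 3 (0.31 log units; beyond the scatter), and compound 2 keeps the lowest number of the series, although these steps remain modest and rest on a single methyl compound. Compound 1 is held at a limit of the assay rather than a number, and an at least 1.7-fold lower number from compound 1 to compound 4 (0.23 log units; that floor lies within the scatter) therefore does not separate iodo from chloro, as the earlier steps from compound 1 to the methyl and methoxy compounds could not fix a true size either: the limit of > 16300 nM in this assay, at which 1 of the 4 values shown sits.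

Going by these compounds, the true number of compound 1 stays open, and with it whether iodo belongs with chloro and methoxy or lies further from them. On these data alone, it also remains open whether an amine, a carboxylic acid or a longer alkyl chain at this same aromatic carbon would move the number outside the narrow span seen so far, and all four compounds leave the rest of the shared core unchanged.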